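Quinoxaline dioxides: swapping a benzyl ether for isopentyl

The source may hold more compounds than are shown below. What is called first, only, known or untested is meant among the compounds shown, and "the series" means these compounds.

Measured so far:
compound 1 `[O-][n+]1nc(NCOCc2ccc(Cl)cc2)[n+]([O-])c2ccccc21` gives 5100 nM
compound 2 `[O-][n+]1nc(NCOCc2ccccc2)[n+]([O-])c2ccccc21` gives 11900 nM

In a functional assay on PC-3 cells (Homo sapiens) for cytotoxicity, read by MTT assay, with a stated time of 72 h (on this read-out higher numbers stand for weaker inhibition and lower numbers for stronger inhibition), compound 2 stands at the highest of the two numbers; compound 1 is nearest, and the step of a 2.3-fold higher number from compound 1 to compound 2 (0.37 log units; beyond the scatter) separates them. Compound 3 `CC(C)CCOCNc1n[n+]([O-])c2ccccc2[n+]1[O-]` is not yet measured. Its difference from compound 2 is isobutyl in place of phenyl on a saturated chain carbon bound to an oxygen on a saturated carbon. Within the data shown here, no measured step touches this change: the only step known concerns a chloro on the ring that is removed here, so it gives no direction. The estimated step is a 1.1-fold higher number from compound 2 to compound 3 (0.04 log units; within the scatter), with wide uncertainty. Compound 3 is expected at 13000 nM, between 4000 nM and 40000 nM.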

Compound 3, half-maximal inhibitory concentration: 7520 nM
The estimate for compound 3 lay 1.7-fold (0.24 log units) above the measured number, and the stated range covers the measured number.
By their numbers in this assay, from the lowest: compounds 1, 3 and 2 (each within the scatter of the next, the first and the last beyond it).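

In this assay, this position accepts a chain with no ring in place of an aromatic one: the swap of benzyl for isopentyl gives a 1.6-fold lower number from compound 2 to compound 3 (0.20 log units; within the scatter), and the comparison with the chlorinated ring gives a 1.5-fold higher number from compound 1 to compound 3 (0.17 log units; within the scatter). An aromatic ring here is therefore not required for activity at this level in these three compounds. Nothing available explains this result. Still open, going by these compounds, is how a longer chain, or an amine or a carboxylic acid in place of isobutyl on this carbon, would read in this assay.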